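The compounds below may be only part of what the source reports. "The series", "measured", "known", "first", "only" and "open" are said of these compounds alone.

Working notes on the series. Compound 1 `CN(C)CCCNc1nc(-c2ccc(NC(=O)Nc3ccccc3Cl)cc2)nc2ccsc12` carries a (2-chlorophenyl)carbamoyl group on its core; in a functional assay on MDA-MB-231 cells (Homo sapiens) for cytotoxicity, read by MTT assay, with a stated time of 72 h (a higher number here means a weaker inhibitor, a lower number a stronger inhibitor), compound 1 gives 590 nM. Compound 2 `CN(C)CCCNc1nc(-c2ccc(NC(=O)Nc3ccc(Cl)cc3Cl)cc2)nc2ccsc12` differs from compound 1 by chloro in place of hydrogen on an aromatic carbon. In this assay compound 2 gives 1860 nM, and the change produced a 3.2-fold higher number from compound 1 to compound 2 (0.50 log units; beyond the scatter). Compound 3 `CN(C)CCCNc1nc(-c2ccc(NC(=O)Nc3ccccc3Cl)cc2)nc2c(Cl)c(Cl)sc12` keeps the (2-chlorophenyl)carbamoyl group of compound 1 on a different core; the difference between the two cores is not broken down here. In this assay compound 3 gives 1560 nM. The values of compound 3 and compound 2 lie within the scatter of each other, while compound 3 stands beyond the scatter from compound 1.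

Compound 4 `CN(C)CCCNc1nc(-c2ccc(NC(=O)Nc3ccc(Cl)cc3Cl)cc2)nc2c(Cl)c(Cl)sc12` has not been measured. Among the compounds with values here, it differs from compound 3 by chloro in place of hydrogen on an aromatic carbon, which is the same change, at the same place by the same description, as the one that leads from compound 1 to compound 2. Within the data shown here, only one measured instance of this change exists, so the expectation rests on it alone, with no second pair to check whether the new core alters the outcome. Among the measured compounds shown here, on this ground the expected step is a 2.9-fold higher number from compound 3 to compound 4 (0.46 log units; beyond the scatter), of the same order as a 3.2-fold higher number from compound 1 to compound 2 (0.50 log units; beyond the scatter), and the range is kept wide to reflect the single precedent. Compound 4 is accordingly estimated at 4500 nM in this assay, with a plausible span from 1800 nM to 11000 nM.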

Compound 4, half-maximal inhibitory concentration: 3490 nM
Beside the measured number, compound 4's estimate is 1.3-fold (0.11 log units) above it; the range from low to high includes it.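

In this assay the change from 2-chlorophenyl to 2,4-dichlorophenyl on the core of compound 3 gives a 2.2-fold higher number from compound 3 to compound 4 (0.35 log units; beyond the scatter) and so moves the number the same way as on the core of compound 1. The two steps do not differ beyond the scatter, so within this pair of cores the change carries over in both direction and size: the same change on two cores in this assay, a 3.2-fold higher number (0.50 log units; beyond the scatter) from compound 1 to compound 2 and a 2.2-fold higher number (0.35 log units; beyond the scatter) from compound 3 to compound 4, 1.4-fold (0.15 log units) apart, within the scatter of two such steps. Within the data shown here, this rests on only two matched pairs in a single cytotoxicity read-out, so it shows no general rule for other cores, and it does not explain why the added chloro gives a higher number on either core.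

From the compounds shown here alone, it remains open whether a methoxy group, a methyl group or a trifluoromethyl group in place of the added chloro would carry across the two cores in the same way, and whether the result would hold with an amine other than the dimethylamino group or with a longer chain at the end of the molecule. It also remains open which part of the difference between the two cores accounts for the gap between compound 1 and compound 3, since the compounds shown do not separate it.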